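A few compounds are considered here, and "the series" means these few. Any claim that something is new, unique, unknown or untested is made for them only; others in the source may bear on it.

Compounds measured in a functional assay on MDA-MB-231 cells (Homo sapiens) for antiproliferative activity, with a stated time of 5 days; a lower number here means a stronger inhibitor, a higher number a weaker inhibitor:
compound 1, `Cc1ccc(-n2nc(-c3ccc4ccccc4c3)nc2N2C(=O)C(C)OC23C=CC(=O)C=C3)cc1`: 100 nM
compound 2, `O=C1C=CC2(C=C1)OCC(=O)N2c1nc(-c2ccc(F)c3ccccc23)nn1-c1ccccc1`: 80 nM
compound 3, `Cc1ccc(-n2nc(-c3ccc4ccccc4c3)nc2N2C(=O)COC23C=CC(=O)C=C3)cc1`: 30 nM

Compound 1 gives the highest of the three numbers in this assay. Compound 2 sits nearest to it, its value lying within the scatter of compound 1, so no order can be read between the two. Compound 3 stands furthest away: a 3.3-fold lower number from compound 1 to compound 3 (0.52 log units; beyond the scatter), a modest step that comes from hydrogen in place of methyl on a saturated ring carbon.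

Compound 4, `CC1OC2(C=CC(=O)C=C2)N(c2nc(-c3ccc4ccccc4c3)nn2-c2ccccc2)C1=O`, is not yet measured. It differs from compound 1 as follows: hydrogen in place of methyl on an aromatic carbon. Among the compounds with values here, the one measured step, that from compound 1 to compound 3, concerns a different place, a methyl on the saturated ring rather than on the aromatic ring, so it bears only loosely on this change. Compound 2 carries a phenyl in place of the 4-methylphenyl but also differs from compound 1 in two further places, so its value only hints that the phenyl is tolerated. On this basis compound 4 is expected to lie close to compound 1, with a step of a 1.4-fold lower number from compound 1 to compound 4 (0.15 log units; within the scatter) that may fall within the scatter. The estimate for compound 4 in this assay is 70 nM, within a range of 30 nM to 170 nM.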

Compound 4, half-maximal inhibitory concentration: 70 nM
Compound 4: the middle estimate sits on the measured number at the digits printed, within the range that was stated.
By their numbers in this assay, from the lowest: compound 3; then compounds 4, 2 and 1 (each within the scatter of the next).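

In this assay, within the data shown here, the change from 4-methylphenyl to phenyl gives a 1.4-fold lower number from compound 1 to compound 4 (0.15 log units; within the scatter) and is the first direct reading at this position, on an aromatic carbon para to a large group. In this single-place comparison, the methyl can leave without a change that can be told from the scatter, so the number of compound 1 does not visibly depend on this methyl. Among these compounds, that differs from the only earlier single-place step, a 3.3-fold lower number from compound 1 to compound 3 (0.52 log units; beyond the scatter) on a saturated ring carbon, which lies beyond the scatter, and no information at hand explains the outcome at the aromatic position.

The compounds shown cover only methyl and hydrogen at this position, so it remains open whether a methoxy group, a chlorine atom, an amine or a carboxylic acid placed there would also leave the number within the scatter. It also remains open whether cells other than the one line shown would respond to this change in the same way.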